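A few compounds are considered here, and "the series" means these few. Any claim that something is new, unique, unknown or untested is made for them only; others in the source may bear on it.

Working notes on the dimethoxyphenol ethane series

Three compounds of this series carry a measured number in a functional assay on HCT-116 cells (Homo sapiens) for antiproliferative activity, read by MTT assay, with a stated time of 72 h; on this read-out lower numbers stand for stronger inhibition and higher numbers for weaker inhibition. Compound 1 `COc1cc(CCc2cccc(Cl)c2Cl)cc(OC)c1O` gives 8780 nM in this assay. Compound 3 `COc1cc(CCc2cccc(F)c2)cc(OC)c1O` gives 7570 nM in this assay. Compound 2 `COc1cc(CCc2ccc(Br)cc2)cc(OC)c1O` gives 15900 nM in this assay, which is the highest of the three numbers; the gap to compound 1 lies within the scatter of repeated measurements, so no order between compound 2 and compound 1 can be read from these two values, whereas the gap to compound 3 lies beyond the scatter, so compound 3 does show the lower number of the two.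

Compound 4 `COc1cc(CCc2ccc(Cl)cc2)cc(OC)c1O` has not been measured in this assay. It differs from compound 2 in one place only: chloro in place of bromo on an aromatic carbon. Within the data shown here, no pair of measured compounds differs in exactly one place, so no measured step offers a direct comparison for this change; the expectation rests on compound 2 alone and on the narrow spread of the three numbers. The exchange of one halogen for another of the same kind at the same place is expected to move the number little, if at all, and the step of a 1.3-fold lower number from compound 2 to compound 4 (0.12 log units; within the scatter) is expected to stay within the scatter. For compound 4 the number in this assay is estimated at 12000 nM, with a range from 6000 nM to 25000 nM.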

Compound 4, half-maximal inhibitory concentration: 330 nM
For compound 4 the middle estimate is 36-fold (1.56 log units) above the measured one; measured number outside the range, below it.
By their numbers in this assay, from the lowest: compound 4; then compounds 3, 1 and 2 (each within the scatter of the next, the first and the last beyond it).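

In this assay, chloro in place of bromo on an aromatic carbon, para to a large group, gives a 48-fold lower number from compound 2 to compound 4 (1.68 log units; beyond the scatter). Among these compounds, this is the only single-place comparison so far, and it shows that this position does not treat the two halogens alike: a change of one heavy atom, with no change in hydrogen-bond donors, acceptors or net charge, is enough to separate compound 2 and compound 4 well beyond the scatter. Nothing at hand bears on why the step is this large.

From the compounds shown here alone, it remains open whether chloro is singular at this place or bromo alone is poorly tolerated there. A nitrile, a trifluoromethyl group or an amine at the same place, on the core of compound 4, would show how far the effect extends.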